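Methoxy in Place of Trifluoromethoxy at a Shared Limit

The compounds below may be only part of what the source reports. "The series", "measured", "known", "first", "only" and "open" are said of these compounds alone.

Compound 3 `C[C@H](Oc1cccc(Cl)c1Cl)C(=O)Nc1ccc2oc(-c3ccc(OC(F)(F)F)cc3)nc2c1` was tested in an assay on isolated protein for inhibition of GMP reductase 2 (Homo sapiens), read by spectrophotometry (a lower number here means a stronger inhibitor, a higher number a weaker inhibitor), where compound 3 gives > 5000 nM, which is a limit of the assay and not a number. Its neighbours give no firmer footing. Compound 2 `C[C@H](Oc1cccc(Cl)c1Cl)C(=O)Nc1ccc2oc(C3=CC=NCC3=O)nc2c1` gives > 5000 nM in this assay, again a limit. Compound 1 `COc1ccc(-c2nc3cc(NC(=O)[C@H](C)Oc4ccccc4CN)ccc3o2)cc1` gives > 5000 nM in this assay, once more a limit. The step from compound 2 to compound 3 is a step that the two limits leave unreadable from compound 2 to compound 3, so the exchange of the six-membered non-aromatic ring for the trifluoromethoxyphenyl group cannot be sized. Every value shown sits at the limit of > 5000 nM in this assay, at which 3 of the 3 values shown sit.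

Compound 4 `COc1ccc(-c2nc3cc(NC(=O)[C@H](C)Oc4cccc(Cl)c4Cl)ccc3o2)cc1` differs from compound 3 by methyl in place of trifluoromethyl on an oxygen on an aromatic ring. Among the compounds with values here, no measured step bears directly on this change; the one step available is unreadable, and compound 1, which carries the same 4-methoxyphenyl group, also rests at the limit. The expected step is a step that the limit leaves unreadable from compound 3 to compound 4, nothing beyond the scatter that can be read. Compound 4 is estimated at 15000 nM, with a range from 4000 nM to 60000 nM, and most likely it too reports only the limit.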

Compound 4, inhibition constant: > 5000 nM
Compound 4: no number, only a limit; the forecaster's own chance of this, stated with the estimate: 80%; the middle value lies beyond the limit too.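

In this assay compound 4 gives > 5000 nM, a limit of the assay and not a number, so its steps from compound 1, compound 2 and compound 3 cannot be read. The compounds shown leave open how strongly each one inhibits, and whether any of these changes alters inhibition at all: the limit of > 5000 nM in this assay, at which 4 of the 4 values shown sit.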